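A few compounds are considered here, and "the series" means these few. Any claim that something is new, unique, unknown or untested is made for them only; others in the source may bear on it.

Compound 1 `CCCCC#Cc1cn([C@H]2C[C@H](O)[C@@H](CO)O2)c(=O)[nH]c1=O` and compound 2 `O=c1[nH]c(=O)n([C@H]2C[C@H](O)[C@@H](CO)O2)cc1C#CCO` share one core and differ only at a saturated chain carbon bound to a triple-bonded carbon. In a functional assay on L1210 cells (Mus musculus) (on this read-out lower numbers stand for stronger inhibition and higher numbers for weaker inhibition), compound 1 gives 1000 ug/mL. Going by these compounds, compound 2 reaches only a limit of this assay, > 1000 ug/mL, so its true number is unknown. Compound 3 `C#Cc1cn(C2O[C@H](CO)[C@@H](O)[C@@H]2O)c(=O)[nH]c1=O`, with a different sugar, gives 45 ug/mL in this assay. Compound 4 `CC#Cc1cn([C@H]2C[C@H](O)[C@@H](CO)O2)c(=O)[nH]c1=O` is not yet measured; it differs from compound 2 by hydrogen in place of hydroxy on a saturated chain carbon bound to a triple-bonded carbon. For the measured compounds named here, the one measured step at that place, a number no lower from compound 1 to compound 2 (the limit leaves the size open), points toward weaker inhibition but its size cannot be read, since compound 2 sits at the limit of > 1000 ug/mL in this assay, at which 1 of the 3 values shown sits. Because compound 1 gives 1000 ug/mL, the step of an at least 1.6-fold lower number from compound 2 to compound 4 (0.22 log units; that floor lies within the scatter) is expected to be small. Compound 4 is expected to give 600 ug/mL, between 150 ug/mL and 1000 ug/mL.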

Compound 4, concentration for 50% inhibition: 164 ug/mL
The estimate for compound 4 lay 3.7-fold (0.56 log units) above the measured number; the range from low to high includes it.
By their numbers in this assay, from the lowest: compound 3; then compound 4; then compound 1.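

In this assay, hydrogen on this saturated chain carbon gives stronger inhibition than either other group there: replacing hydroxy gives an at least 6.0-fold lower number from compound 2 to compound 4 (0.78 log units; beyond the scatter), and replacing propyl gives a 6.1-fold lower number from compound 1 to compound 4 (0.79 log units; beyond the scatter). Both additions to the prop-1-yn-1-yl group of compound 4 therefore go with weaker inhibition, so this carbon is sensitive to change. Compound 2 sits at a limit, so its step gives only a floor: the limit of > 1000 ug/mL in this assay, at which 1 of the 4 values shown sits.

Going by these compounds, whether an amine or a carboxylic acid on this carbon would keep the inhibition of compound 4 stays open. Compound 3 differs in its sugar as well, so it cannot settle this.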